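Amide cap variation around compound 1

A few compounds are considered here, and "the series" means these few. Any claim that something is new, unique, unknown or untested is made for them only; others in the source may bear on it.

Measured in an assay on isolated protein for binding affinity to secreted frizzled-related protein 1 (Homo sapiens), read by fluorescence; on this read-out lower numbers stand for stronger inhibition and higher numbers for weaker inhibition:
compound 1 `CN(C)CC(=O)N1CCC(NS(=O)(=O)c2cc(S(=O)(=O)c3ccccc3)ccc2C(F)(F)F)CC1` — 300 nM
compound 2 `O=C(Cn1ccnc1)N1CCC(NS(=O)(=O)c2cc(S(=O)(=O)c3ccccc3)ccc2C(F)(F)F)CC1` — 30 nM
compound 3 `CC(C)(C)C(=O)N1CCC[C@H]1C(=O)N1CCC(NS(=O)(=O)c2cc(S(=O)(=O)c3ccccc3)ccc2C(F)(F)F)CC1` — 40 nM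

Compound 1 gives the highest number of the three. Two steps start from it: a 10-fold lower number from compound 1 to compound 2 (1.00 log units; beyond the scatter) and a 7.5-fold lower number from compound 1 to compound 3 (0.88 log units; beyond the scatter). Between the two lower compounds the step is a 1.3-fold higher number from compound 2 to compound 3 (0.12 log units; within the scatter). Compound 4 `CC(C)(C)CC(=O)N1CCC[C@H]1C(=O)N1CCC(NS(=O)(=O)c2cc(S(=O)(=O)c3ccccc3)ccc2C(F)(F)F)CC1` awaits measurement; it differs from compound 1 as follows: 1-(neopentylcarbonyl)pyrrolidin-2-yl in place of (dimethylamino)methyl on a carbonyl carbon. The step to compound 3 bears most directly on this change, as compound 3 and compound 4 share the pyrrolidin-2-yl amide and differ only in neopentylcarbonyl against (tert-butyl)carbonyl. A step of similar size towards lower numbers is therefore expected, a 7.5-fold lower number from compound 1 to compound 4 (0.88 log units; beyond the scatter). Compound 4 is estimated at 40 nM, within 15 nM to 120 nM.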

Compound 4, half-maximal inhibitory concentration: 20 nM
The estimate for compound 4 lay 2.0-fold (0.30 log units) above the measured number; the range from low to high includes it.
By their numbers in this assay, from the lowest: compounds 4, 2 and 3 (each within the scatter of the next); then compound 1.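

In this assay the acyl group on the pyrrolidin-2-yl cap accepts neopentyl in place of tert-butyl, giving a 2.0-fold lower number from compound 3 to compound 4 (0.30 log units; within the scatter), so these two groups are not separated here. The 1-(neopentylcarbonyl)pyrrolidin-2-yl and (1H-imidazol-1-yl)methyl caps are likewise not separated, with a 1.5-fold lower number from compound 2 to compound 4 (0.18 log units; within the scatter), whereas the step away from (dimethylamino)methyl is a 15-fold lower number from compound 1 to compound 4 (1.18 log units; beyond the scatter). Nothing available explains these steps.

Open, going by these compounds, is whether a longer chain than neopentyl, or a carboxylic acid in its place, keeps the number at this level. Also open, on these data alone, is how the opposite configuration at the pyrrolidin-2-yl stereocentre would read.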